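Dropping the Trifluoromethyl from the Benzamide in Prostate Cells

The compounds below may be only part of what the source reports. "The series", "measured", "known", "first", "only" and "open" are said of these compounds alone.

Three compounds sharing one core were tested in a functional assay on PC-3 cells (Homo sapiens) for inhibition, read by sulforhodamine B assay, with a stated time of 48 h; on this read-out higher numbers stand for lower toxicity in this test and lower numbers for higher toxicity in this test. Compound 1 `COc1cc(-c2nn(-c3cccc(NC(=O)c4ccc(Cl)c(C(F)(F)F)c4)c3)cc2-c2ccncc2)ccc1Cl` gives only a limit of the test, > 32500 nM. Compound 2 `COc1cc(-c2nn(-c3cccc(NC(=O)c4cccc(C(F)(F)F)c4)c3)cc2-c2ccncc2)ccc1Cl` likewise gives only a limit, > 50000 nM. Compound 3 `O=C(Nc1cccc(-n2cc(-c3ccncc3)c(-c3ccc(Cl)c(O)c3)n2)c1)Nc1cc(C(F)(F)F)cc(C(F)(F)F)c1` also stops at a limit, > 50000 nM. So compound 2 stands among values that are limits rather than numbers. The step that the two limits leave unreadable from compound 1 to compound 2 is hydrogen in place of chloro on an aromatic carbon, and its size cannot be read, as it sits between the limit of > 32500 nM in this assay, at which 1 of the 3 values shown sits, and (the limit of > 50000 nM in this assay, at which 2 of the 3 values shown sit). Compound 4 `COc1cc(-c2nn(-c3cccc(NC(=O)c4ccccc4)c3)cc2-c2ccncc2)ccc1Cl` differs from compound 2 by hydrogen in place of trifluoromethyl on an aromatic carbon. No readable measured step bears on this change, so no step beyond the scatter is expected in this assay. Compound 4 is estimated at 50000 nM, between 15000 nM and 100000 nM, a step of a number no higher from compound 2 to compound 4 (the limit leaves the size open), most probably again reported as a limit.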

Compound 4, concentration lethal to 50% of the cells: > 100000 nM
Compound 4 was reported as a limit (the forecaster's own chance of this, stated with the estimate: 70%); middle value at least 2.0-fold (0.30 log units) from the limit.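

Compound 4 stops at a limit, > 100000 nM, and the steps to it from compound 1 and compound 2 cannot be read. The compounds shown leave open whether any of the four has a lethal concentration expressible as a number in this assay.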